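Fluorine on the Phenyl Ring of an Analgesic Series

The source may report more compounds than this note shows. Statements on the series, on what has been measured and on what is new or still open speak of the compounds shown alone.

Measured so far:
Compound 1, `O=c1oc2ncccc2n1CCN1CCN(c2ccccc2)CC1` — 25 mg/kg
Compound 2, `O=c1oc2ncccc2n1CCCN1CCN(c2ccccc2)CC1` — 12.7 mg/kg

Of the compounds shown here, two have been tested in a functional assay on the whole organism with Mus musculus as the target, in the writhing test; on this read-out higher numbers stand for an effect only at larger amounts of compound and lower numbers for an effect already at smaller amounts. Compound 1 is `O=c1oc2ncccc2n1CCN1CCN(c2ccccc2)CC1` and in this assay compound 1 gives 25 mg/kg. Compound 2 is `O=c1oc2ncccc2n1CCCN1CCN(c2ccccc2)CC1` and in this assay compound 2 gives 12.7 mg/kg. Compound 2 has the lowest of the two numbers, but its nearest neighbour, compound 1, lies within the usual scatter of such measurements, so the two values cannot be told apart with confidence.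

The next compound, compound 3, is `O=c1oc2ncccc2n1CCCN1CCN(c2ccc(F)cc2)CC1`. It differs from compound 2 by a single change: fluoro in place of hydrogen on an aromatic carbon. Among the compounds with values here, no comparable pair among the measured compounds shows how such an exchange affects the outcome in this assay, so there is nothing to copy from. The change is small, adding one atom at the outer edge of the molecule, and the expectation is a step of no more than the scatter, in either direction.

On that basis compound 3 is expected to give about 11 mg/kg, with a plausible range from 4 mg/kg to 30 mg/kg; this estimate amounts to a step of a 1.2-fold lower number from compound 2 to compound 3 (0.06 log units; within the scatter).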

Compound 3, dose for half-maximal effect: 5.6 mg/kg
Compound 3: the middle estimate sits 2.0-fold (0.29 log units) above what was measured, and the stated range covers the measured number.
By their numbers in this assay, from the lowest: compound 3; then compounds 2 and 1 (each within the scatter of the next).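

In this assay, the exchange of phenyl for 4-fluorophenyl gives a 2.3-fold lower number from compound 2 to compound 3 (0.36 log units; beyond the scatter), a modest step but one that stands clear of the usual scatter, whereas the values of compound 1 and compound 2 could not be told apart. This shows that the position para to a large group on this aromatic ring is not indifferent: a single fluorine there is enough to shift the effect to smaller amounts of compound, at least on the side chain that compound 2 and compound 3 share. Why the number moves in this direction remains unexplained, as no measurement at hand bears on the reason.

Within the data shown here, with only this one pair, it remains open whether the step belongs to fluorine itself or would also appear with another group in the same place, such as chloro, methyl or methoxy. As far as these compounds go, it is equally open whether 4-fluorophenyl would bring a similar step on the shorter chain of compound 1, or whether the step seen here holds only with the longer chain.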